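Removing a fluorine from a methylsulfonyl-bearing benzamide

A few compounds are considered here, and "the series" means these few. Any claim that something is new, unique, unknown or untested is made for them only; others in the source may bear on it.

This series shares a core in which a piperidine carries a benzoyl group at one end and a sulfonamide at the other. Compound 1 `O=C(c1ccccc1)N1CCC(N(C2CC2)S(=O)(=O)c2cccc(C(F)(F)F)c2)CC1` has a plain benzoyl group, compound 2 `CS(=O)(=O)c1ccc(C(=O)N2CCC(N(C3CC3)S(=O)(=O)c3cccc(C(F)(F)F)c3)CC2)cc1` adds a methylsulfonyl group to that benzoyl ring, and compound 3 `CS(=O)(=O)c1ccc(F)cc1C(=O)N1CCC(N(C2CC2)S(=O)(=O)c2cccc(C(F)(F)F)c2)CC1` carries both a methylsulfonyl group and a fluoro on it. In an assay on cells for inhibition of Voltage-dependent L-type calcium channel subunit alpha-1C (Homo sapiens), read by FLIPR and calcium flux, tested at 1 uM (a higher number here means a stronger effect of the compound at the concentration tested, a lower number a weaker effect), compound 1 gives "not determined" (no result reported), and in this assay compound 2 gives "not determined" (no result reported). In this assay, among the compounds with values here, compound 3 gives 18%, which is the only number available here, so it cannot be ranked against anything.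

Compound 4 `CS(=O)(=O)c1ccccc1C(=O)N1CCC(N(C2CC2)S(=O)(=O)c2cccc(C(F)(F)F)c2)CC1` differs from compound 3 in one place: hydrogen in place of fluoro on an aromatic carbon. Within the data shown here, no measured pair in this set shows what such a change does, so the expectation rests on the single value of compound 3 alone. The expected step of a number 3 percentage points lower from compound 3 to compound 4 (within the scatter) is therefore small, within the usual scatter, in no particular direction. For compound 4, the inhibition in this assay is estimated at 15%, with a range from 0% to 35%.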

Compound 4, a percentage reported as inhibition, at one concentration (the size of the read-out at that concentration, not a potency): 19%
Compound 4: the middle estimate sits 4 percentage points below what was measured, within the range that was stated.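

In this assay, within the data shown here, the step of a number 1 percentage points higher from compound 3 to compound 4 (within the scatter) is the first one-place comparison in this set that can be read. It shows that, at this position para to a methylsulfonyl group, the difference between fluoro and hydrogen does not exceed the usual scatter of the read-out, so the fluoro is not needed to retain this level of inhibition. No supporting measurement here accounts for this result.

Fluoro and hydrogen are only two options, so the compounds shown leave open whether a larger or differently built group at the same position, such as an amine, a methoxy group or a carboxylic acid, would give a different read-out. Going by these compounds, the role of the methylsulfonyl group also stays open, as compound 1 and compound 2 have no numbers and their comparisons cannot be read.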